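The source may hold more compounds than are shown below. What is called first, only, known or untested is meant among the compounds shown, and "the series" means these compounds.

Working notes on the series. Of the compounds shown here, two have been measured so far: compound 1 `Oc1ccc(/C=N/NC(=S)Nc2ccc(Cl)cc2)cc1` and compound 2 `Cc1ccc(NC(=S)N/N=C/c2ccc(O)cc2)cc1`, which share one core and differ only in the group on one aromatic carbon. In an assay for inhibition of ribonucleoside-diphosphate reductase RR1 (Homo sapiens), with a stated time of 30 min (on this read-out higher numbers stand for weaker inhibition and lower numbers for stronger inhibition), compound 1 gives 287000 nM. In this assay, within the data shown here, compound 2 gives 14200 nM, the lowest of the two numbers recorded; the single step between them, a 20-fold lower number from compound 1 to compound 2 (1.31 log units; beyond the scatter), is methyl in place of chloro on an aromatic carbon.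

Compound 3 `O=[N+]([O-])c1ccc(NC(=S)N/N=C/c2ccc(O)cc2)cc1` has not yet been measured. Its structure differs from compound 2 by nitro in place of methyl on an aromatic carbon of a six-membered aromatic ring of carbon only, para to a large group. Among the measured compounds shown here, the only step that bears on this change is a 20-fold lower number from compound 1 to compound 2 (1.31 log units; beyond the scatter), since it alters the group on the same carbon; it shows that an exchange at this position can move the number by a large amount, but chloro is not nitro, and no other pair informs the direction. The estimate for compound 3 in this assay is therefore wide, set at 60000 nM with a range from 10000 nM to 350000 nM, which corresponds to an expected step of a 4.2-fold higher number from compound 2 to compound 3 (0.63 log units; beyond the scatter).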

Compound 3, half-maximal inhibitory concentration: 45100 nM
Estimate against measurement, compound 3: 1.3-fold (0.12 log units) above; low and high end bracket the measured number.
By their numbers in this assay, from the lowest: compound 2; then compound 3; then compound 1.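

In this assay nitro gives a 3.2-fold higher number from compound 2 to compound 3 (0.50 log units; beyond the scatter) and a 6.4-fold lower number from compound 1 to compound 3 (0.80 log units; beyond the scatter) as its second step, so a third group on this aromatic carbon falls inside the range already set by methyl and chloro. The order from the lowest number is now methyl, nitro, chloro, and each gap between neighbours is printed as beyond the scatter, which shows that this position separates more than the two groups first compared. Nitro brings more heavy atoms than methyl and brings hydrogen-bond acceptors, yet methyl keeps the lowest number of the three, and no measured property of these groups is at hand to account for that order.

As far as these compounds go, whether an amine, a methoxy group or a carboxylic acid on this carbon would fall within the same range, or whether an ethyl group or a longer chain would go lower than methyl, remains open. From the compounds shown here alone, all three compounds also keep the rest of the shared core unchanged, so it is equally open whether this order of groups would hold with a change elsewhere on that core.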